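Swapping a methylamine arm for an ethyl amide

This account rests on a few compounds, and the source may have more. Where it says the series, first, only, none or still open, it means among the compounds named here.

compound 1, `CCCCCOC(=O)N1CCN(C(=O)[C@H](CCC(=O)O)NC(=O)c2cc(N3CCC(COC)CC3)nc(-c3ccccc3)n2)CC1`: > 80%
compound 2, `CCCCCOC(=O)N1CCN(C(=O)[C@H](CCC(=O)O)NC(=O)c2cc(N3CCC(CNC)CC3)nc(-c3ccccc3)n2)CC1`: > 80%

Both compounds were tested in an ADME assay on microsomes from liver (Rattus norvegicus) for metabolic stability; a lower number here means that less of the compound is left, a higher number that more of the compound is left. In this assay compound 1 gives > 80%, which is a limit of the assay rather than a number. In this assay compound 2 likewise gives > 80%, again a limit of the assay. Going by the values given here, compound 2 therefore stands where every value so far stands, namely at the limit of > 80% in this assay, at which 2 of the 2 values shown sit. Among the compounds with values here, the one measured step, a step that the two limits leave unreadable from compound 1 to compound 2, cannot be sized because of the limit of > 80% in this assay, at which 2 of the 2 values shown sit.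

Compound 3, `CCCCCOC(=O)N1CCN(C(=O)[C@H](CCC(=O)O)NC(=O)c2cc(N3CCC(C(=O)NCC)CC3)nc(-c3ccccc3)n2)CC1`, is not yet measured. It differs from compound 2 in one place: ethylcarbamoyl in place of (methylamino)methyl on a saturated ring carbon. Within the data shown here, no measured step involves ethylcarbamoyl, and the only step available, a step that the two limits leave unreadable from compound 1 to compound 2, gives no readable size, so nothing in the data points to a change in this assay beyond the scatter. Compound 3 is therefore expected to give about 88% in this assay, within 72% to 100%, which amounts to an expected step that the limit leaves unreadable from compound 2 to compound 3 and most likely once more only a limit.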

Compound 3, percent of the compound remaining: > 80%
Compound 3 gave a limit, no number (the forecaster's own chance of this, stated with the estimate: 75%); the middle value is on the limit's open side.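

In this assay compound 3 gives > 80%, which is a limit of the assay and not a number. No step among compound 1, compound 2 and compound 3 can be sized, because all three sit at the same limit: the limit of > 80% in this assay, at which 3 of the 3 values shown sit.

The compounds shown leave open how much of each compound remains, and whether methoxymethyl, (methylamino)methyl and ethylcarbamoyl differ at all in this assay.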